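The source may report more compounds than this note shows. Statements on the series, on what has been measured and on what is new or still open speak of the compounds shown alone.

Measured compounds:
compound 1, `C/C=C/C(=O)Nc1cccc(-c2nc3ccccc3s2)c1`; in an ADME assay on HEK293 cells (Homo sapiens) for inhibition, with a stated time of 72 h (a lower number here means that less compound is needed, a higher number that more compound is needed for the effect), compound 1 gives > 25000 nM, a limit of the assay.
compound 2, `CC(Cl)C(=O)Nc1cccc(-c2nc3ccccc3s2)c1`; in this assay compound 2 gives > 25000 nM, again a limit.
compound 3, `O=C(Nc1cccc(-c2nc3ccccc3s2)c1)c1ccc(Cl)nc1Cl`; in this assay compound 3 gives > 25000 nM, also a limit.

Compound 3 therefore stands at the limit of this assay, alongside the other two measured compounds, and no number separates any of them. The unmeasured compound 4, `O=C(Nc1cccc(-c2nc3ccccc3s2)c1)c1cnc(Cl)s1`, differs from compound 3 in one place: 2-chloro-1,3-thiazol-5-yl in place of 2,6-dichloropyridin-3-yl on a carbonyl carbon.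

Going by the values given here, three measured steps touch the same carbonyl carbon: a step that the two limits leave unreadable from compound 1 to compound 2, a step that the two limits leave unreadable from compound 1 to compound 3 and a step that the two limits leave unreadable from compound 2 to compound 3. None of them can be read, because the limit of > 25000 nM in this assay, at which 3 of the 3 values shown sit, leaves no number on either side. Among the compounds with values here, they show only that three different groups on that carbonyl carbon all fall outside the measurable range of this assay. The change to compound 4 is of the same kind, and nothing in the measured steps points to a readable effect in either direction.

Compound 4 is accordingly expected to give about 25000 nM in this assay, within 8000 nM to 60000 nM. The step from compound 3 that this estimate means is a number no higher from compound 3 to compound 4 (the limit leaves the size open), most likely reported again only as a limit.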

Compound 4, half-maximal effective concentration: > 25000 nM
Compound 4: only a limit was reported (the forecaster's own chance of this, stated with the estimate: 80%); the middle value lies on the limit itself.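

No step from compound 1, compound 2 or compound 3 to compound 4 can be read in this assay, because all four compounds share one limit: the limit of > 25000 nM in this assay, at which 4 of the 4 values shown sit.

The compounds shown leave open how far apart these four compounds truly lie, and whether any group on the carbonyl carbon gives a value inside the measurable range.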